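Benzyl for cyclohexyl on an aromatic nitrogen: series notes

The source may report more compounds than this note shows. Statements on the series, on what has been measured and on what is new or still open speak of the compounds shown alone.

Compound 1 `O=Cc1ccc(-c2cn3ccnc3c(-c3ccc4ncn(C5CCCCC5)c4c3)n2)cc1` and compound 2 `O=Cc1ccc(-c2cn3ccnc3c(-c3ccc4ncn(Cc5ccccc5)c4c3)n2)cc1` share a core and differ by benzyl in place of cyclohexyl on an aromatic nitrogen. In a functional assay on U-251 cells (Homo sapiens) for inhibition, read by sulforhodamine B assay, with a stated time of 48 h, tested at 10 uM (a higher number here means more inhibition at the concentration tested (going by the name of the read-out), a lower number less inhibition), compound 1 gives 32%, and compound 2 gives 32%; the step of no change at the digits printed from compound 1 to compound 2 (within the scatter). Compound 3 `c1cn2cc(-c3ccc4c(c3)ncn4C3CCCCC3)nc(-c3ccc4ncn(C5CCCCC5)c4c3)c2n1` gives 38.7% in this assay; how its core differs from that of compound 1 is not broken down here, and the two values lie within the scatter of each other. Compound 4 `c1ccc(Cn2cnc3ccc(-c4nc(-c5ccc6c(c5)ncn6C5CCCCC5)cn5ccnc45)cc32)cc1` is not yet measured. It differs from compound 3 by benzyl in place of cyclohexyl on an aromatic nitrogen, the same change as that from compound 1 to compound 2, at the same place. The step of a number 1.7 percentage points lower from compound 3 to compound 4 (within the scatter) is expected to be small, because no change at the digits printed from compound 1 to compound 2 (within the scatter). Compound 4 is therefore estimated at 37% in this assay, between 25% and 50%.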

Compound 4, a percentage reported as inhibition, at one concentration (the size of the read-out at that concentration, not a potency): -22.8%
Beside the measured number, compound 4's estimate is 59.8 percentage points above it; the whole stated range lies above it.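

On the core of compound 3, benzyl in place of cyclohexyl on an aromatic nitrogen gives a number 61.5 percentage points lower from compound 3 to compound 4 (beyond the scatter) in this assay. The change therefore does not carry over unaltered from the core of compound 1 to that of compound 3: the same change on two cores in this assay, no change at the digits printed (within the scatter) from compound 1 to compound 2 and a number 61.5 percentage points lower (beyond the scatter) from compound 3 to compound 4, 61.5 percentage points apart, beyond the scatter of two such steps. This rests on a single pair per core: it shows that the outcome of this change depends on the core in these four compounds, but not which feature of the core is responsible or how the change would behave on a further core.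

The compounds shown leave open how the same change behaves at the second cyclohexyl of compound 4. They also leave open how a longer alkyl chain or a chain ending in an amine would read on that nitrogen.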